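The compounds below may be only part of what the source reports. "The series", "measured", "known", "first", "only" and "open" are said of these compounds alone.

Working notes on the series: in a functional assay on B16-F10 cells (Mus musculus) for cytotoxicity, read by MTT assay, with a stated time of 48 h (on this read-out higher numbers stand for weaker inhibition and lower numbers for stronger inhibition), compound 1 `Cc1ccc2nc(Nc3nc4ccccc4s3)sc2c1` gives > 50000 nM, which is a limit of the assay and not a number. Compound 1 therefore stands at the limit of > 50000 nM in this assay, at which 1 of the 2 values shown sits. Compound 2 `Cc1ccc2nc(Nc3nc4ccc(F)cc4s3)sc2c1` gives 29600 nM. Compound 3 `c1ccc2sc(Nc3nc4ccccc4s3)nc2c1` has hydrogen in place of methyl on an aromatic carbon. Within the data shown here, no measured step covers this exchange. The nearest evidence is compound 2, with an at least 1.6-fold lower number from compound 1 to compound 2 (0.22 log units; that floor lies within the scatter), which is a different change on the shared core and gives only weak guidance. On that basis, no clear move in either direction is expected in this assay. The expected change is a number no higher from compound 1 to compound 3 (the limit leaves the size open), with no shift beyond the scatter anticipated. Compound 3 is estimated at 50000 nM, with an expected range from 25000 nM to 100000 nM.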

Compound 3, half-maximal inhibitory concentration: > 50000 nM
Compound 3 gave a limit, no number; the forecaster's own chance of this, stated with the estimate: 60%; the middle value lies on the limit itself.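

Compound 1 and compound 3 each give a limit and not a number, so no step can be read between them: the limit of > 50000 nM in this assay, at which 2 of the 3 values shown sit.

The compounds shown leave open whether hydrogen in place of methyl on an aromatic carbon shifts the number in either direction, and by how much.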